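Bromo in place of nitro at the aromatic carbon

This account rests on a few compounds, and the source may have more. Where it says the series, first, only, none or still open, it means among the compounds named here.

In a functional assay with Felis catus as the target (a lower number here means that less compound is needed, a higher number that more compound is needed for the effect), compound 1 `CCNc1nc(C)nc(O)c1C#N` gives 300000 nM, and compound 2 `CCNc1nc(C)nc(O)c1[N+](=O)[O-]` gives 230000 nM. Compound 3 `Cc1nc(O)c([N+](=O)[O-])c(NCc2cccnc2)n1` is recorded only as a limit, > 1000000 nM. Among the compounds with values here, compound 2 therefore stands level with compound 1, within the scatter, and these are the only two numbers available.

Compound 4 `CCNc1nc(C)nc(O)c1Br` carries bromo in place of nitro on an aromatic carbon, ortho to a hydroxy group and ortho to an ethylamino group: bromo in place of nitro on an aromatic carbon. The measured step at this same carbon, nitro in place of cyano, is a 1.3-fold lower number from compound 1 to compound 2 (0.12 log units; within the scatter). The other measured step, an at least 4.3-fold higher number from compound 2 to compound 3 (0.63 log units; beyond the scatter), puts pyridin-3-yl in place of methyl on the chain and says little about this carbon. Within the data shown here, no bromo compound has been measured, so the range stays wide. No change beyond the scatter is expected in this assay, and the expected step is a 1.3-fold higher number from compound 2 to compound 4 (0.12 log units; within the scatter). Compound 4 is expected at 300000 nM, with an estimated range of 100000 nM to 800000 nM.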

Compound 4, half-maximal effective concentration: 420000 nM
Beside the measured number, compound 4's estimate is 1.4-fold (0.15 log units) below it, and the stated range covers the measured number.
By their numbers in this assay, from the lowest: compounds 2, 1 and 4 (each within the scatter of the next). At a limit, above all of these: compound 3.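

In this assay bromo in place of nitro gives a 1.8-fold higher number from compound 2 to compound 4 (0.26 log units; within the scatter), and bromo in place of cyano gives a 1.4-fold higher number from compound 1 to compound 4 (0.15 log units; within the scatter). Compound 1, compound 2 and compound 4 therefore stand level, so this aromatic carbon tolerates all three groups in this assay without a step beyond the scatter, even though bromo enters with 1 heavy atom and 0 hydrogen-bond acceptors where nitro leaves with 3 heavy atoms and 2 hydrogen-bond acceptors. Nothing in the data shown accounts for this flat result.

Going by these compounds, whether an amine, a carboxylic acid or a methoxy group on this carbon would move the number beyond the scatter stays open. On these data alone, the effect of a longer chain in place of the ethyl group, with bromo kept on this carbon, is equally open.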